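Replacing a Basic Amine with a Hydroxy Group

The source may report more compounds than this note shows. Statements on the series, on what has been measured and on what is new or still open speak of the compounds shown alone.

Measured so far:
- compound 1 `C=CCCn1c(=O)c2[nH]cnc2n(CCC)c1=O`: 60 nM
- compound 2 `CCCn1c(=O)n(CC(=O)O)c(=O)c2[nH]cnc21`: > 200000 nM
- compound 3 `CCCn1c(=O)n(CCN(C)C)c(=O)c2[nH]cnc21`: 4300 nM

In an assay on Cerebral cortex for binding affinity to adenosine receptor A1 (Cavia porcellus), read by radioligand binding (on this read-out higher numbers stand for weaker inhibition and lower numbers for stronger inhibition), compound 3 stands highest of the two numbers given, with compound 1 nearest at a 72-fold higher number from compound 1 to compound 3 (1.86 log units; beyond the scatter). Compound 2 gives only a limit of the assay in this assay (the limit of > 200000 nM in this assay, at which 1 of the 3 values shown sits). The next compound, compound 4 `CCCn1c(=O)n(CCO)c(=O)c2[nH]cnc21`, differs from compound 3 by hydroxy in place of dimethylamino on a saturated chain carbon, two bonds along the chain from an aromatic nitrogen. Going by the values given here, no measured step swaps these two groups; the nearest are a 72-fold higher number from compound 1 to compound 3 (1.86 log units; beyond the scatter) and an at least 46-fold lower number from compound 2 to compound 3 (1.66 log units; beyond the scatter), which show that the side chain on this nitrogen moves the number strongly in both directions. A hydroxy group has not been tested here, so the expectation is uncertain: compound 4 is estimated at 2000 nM, between 400 nM and 10000 nM, meaning an expected 2.2-fold lower number from compound 3 to compound 4 (0.33 log units; beyond the scatter).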

Compound 4, inhibition constant: 50000 nM
Beside the measured number, compound 4's estimate is 25-fold (1.40 log units) below it; the whole stated range lies below it.
By their numbers in this assay, from the lowest: compound 1; then compound 3; then compound 4. At a limit, above all of these: compound 2.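

Putting hydroxy in place of dimethylamino at the end of this chain weakens binding, with a 12-fold higher number from compound 3 to compound 4 (1.07 log units; beyond the scatter), so a small change at this position has a large effect. The same chain stays far weaker than the chain of compound 1, with an 830-fold higher number from compound 1 to compound 4 (2.92 log units; beyond the scatter), yet hydroxymethyl in place of carboxy still gives an at least 4.0-fold lower number from compound 2 to compound 4 (0.60 log units; beyond the scatter). Compound 2 gives only a limit, not a true number: the limit of > 200000 nM in this assay, at which 1 of the 4 values shown sits.

As far as these compounds go, whether a methoxy group or a primary amine at this place would bind better than hydroxy remains open. So does the effect of a longer chain carrying the hydroxy.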